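Side-chain step from compound 2 to compound 3

The compounds below may be only part of what the source reports. "The series", "measured", "known", "first", "only" and "open" are said of these compounds alone.

Measured in a functional assay (trachea) with Cavia porcellus as the target; a higher number here means that more compound is needed for the effect, a lower number that less compound is needed:
- compound 1 `CCCn1c(=O)n(C)c(=O)c2c1ncn2CC(N)=O`: > 100000 nM (a limit)
- compound 2 `CCCn1c(=O)n(C)c(=O)c2c1ncn2CCO`: 31800 nM

For the measured compounds named here, compound 2 gives 31800 nM, the only actual number so far. Compound 1 gives > 100000 nM, which is a limit. The remaining evidence in this assay is thus (the limit of > 100000 nM in this assay, at which 1 of the 2 values shown sits).

Compound 3 `CCCn1c(=O)n(C)c(=O)c2c1ncn2CC(C)=O` carries acetyl in place of hydroxymethyl on a saturated chain carbon bound to an aromatic nitrogen.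

Going by the values given here, one measured step bears on this change, as it sits at the same place: an at least 3.1-fold lower number from compound 1 to compound 2 (0.49 log units; beyond the scatter). It starts from a limit and fixes only a minimum size. Acetyl holds a carbonyl, as does the carbamoyl of compound 1, and that gives a slight lean towards a higher number than that of compound 2. With a single step as a guide, no change beyond the scatter is expected. The expected step is a 1.3-fold higher number from compound 2 to compound 3 (0.10 log units; within the scatter). For compound 3 the estimate is 40000 nM, with an expected range of 13000 nM to 100000 nM.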

Compound 3, half-maximal effective concentration: 1900 nM
The estimate for compound 3 lay 21-fold (1.32 log units) above the measured number, and the stated range ends above it.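

In this assay, for the compounds shown here, this position on a saturated chain carbon bound to an aromatic nitrogen proves far more responsive than the earlier compounds could show: acetyl in place of hydroxymethyl gives a 17-fold lower number from compound 2 to compound 3 (1.22 log units; beyond the scatter). Methyl in place of amino on a carbonyl carbon gives an at least 52-fold lower number from compound 1 to compound 3 (1.72 log units; beyond the scatter), a step that starts from a limit and so fixes only a minimum size. A carbonyl alone therefore does not set the number: compound 1 and compound 3 both hold one, yet compound 3 has the lowest number of the three, while compound 2, without a carbonyl, lies between them, so the group on the carbonyl carbon matters.

Still open, as far as these compounds go, is which difference between hydroxymethyl and acetyl goes with the step, as the loss of the hydrogen-bond donor, the gain of the carbonyl and the added carbon all arrive together in this one change. Also open, from the compounds shown here alone, is how far the trend extends on the carbonyl carbon, for instance with propanoyl in place of acetyl, or how a carboxylic acid would read at this place.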